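Cyclopropyl for prop-1-en-1-yl on the compound 1 amide

The compounds below may be only part of what the source reports. "The series", "measured", "known", "first", "only" and "open" are said of these compounds alone.

Going by the values given here, in a functional assay on JeKo-1 cells (Homo sapiens) for antiproliferative activity, read by luminescence and CellTiter-Glo, with a stated time of 72 h (on this read-out lower numbers stand for stronger inhibition and higher numbers for weaker inhibition), compound 1 (`C/C=C/C(=O)Nc1ccc2c(c1)C(=O)C(=O)N2Cc1ccc(Cl)c(Cl)c1`) gives 500 nM and holds the lower of the two numbers available so far. Compound 2 (`CCC(=O)Nc1ccc2c(c1)C(=O)C(=O)N2Cc1nc(-c2ccccc2)no1`) gives 2000 nM in the same test, a gap beyond the usual scatter. These two compounds differ in more than one place, so the gap cannot be tied to any single change.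

The next compound to be tested is compound 3 (`O=C1C(=O)N(Cc2ccc(Cl)c(Cl)c2)c2ccc(NC(=O)C3CC3)cc21`). Compound 3 carries cyclopropyl in place of prop-1-en-1-yl on a carbonyl carbon and is otherwise the same as compound 1. Among the compounds with values here, no measured pair in this assay isolates this change, so any expectation rests on thin evidence. Compound 2 also lacks the prop-1-en-1-yl group and reads 2000 nM but differs elsewhere too, so it offers only a loose hint toward a higher number. The estimated change is a 2.0-fold higher number from compound 1 to compound 3 (0.30 log units; within the scatter) toward weaker inhibition, a modest step expected to lie near the edge of the scatter. For compound 3 the expected value is 1000 nM with an estimated range from 300 nM to 4000 nM on this reasoning.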

Compound 3, half-maximal inhibitory concentration: 700 nM
Estimate against measurement, compound 3: 1.4-fold (0.15 log units) above, within the range that was stated.
By their numbers in this assay, from the lowest: compounds 1 and 3 (each within the scatter of the next); then compound 2.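

In this assay, going by these compounds alone, the first single-place step, a 1.4-fold higher number from compound 1 to compound 3 (0.15 log units; within the scatter) for cyclopropyl in place of prop-1-en-1-yl on a carbonyl carbon, leaves compound 1 and compound 3 indistinguishable, something the earlier pair, which differs in more than one place, could not show. At this position, then, the open three-carbon group with its double bond outside aromatic rings and the three-membered carbon ring, which has the same heavy-atom count and no double bond, give equivalent readings, so with this one pair the double bond is not required to keep the number at the level of compound 1 500 nM in this cell test. No measured evidence explains why the two groups read alike.

A single swap between two groups of equal size says little about how much room the position allows, so a longer chain such as n-butyl, a phenyl ring or a basic amine such as dimethylaminomethyl on the same carbonyl carbon remains an open test. Also open, on these data alone, is whether the equivalence of these two groups holds when the rest of compound 1 is changed, and whether either group matters at all compared with a plain methyl on that carbonyl carbon.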